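Ethoxy for methoxy on the anilide ring: second occurrence

This account rests on a few compounds, and the source may have more. Where it says the series, first, only, none or still open, it means among the compounds named here.

Measured compounds:
compound 1, `COc1ccc(NC(=O)C2Cc3cc(OC)c(OC)cc3C2=O)cc1`: 49.5 ug/mL
compound 2, `CCOc1ccc(NC(=O)C2Cc3cc(OC)c(OC)cc3C2=O)cc1`: 48.2 ug/mL
compound 3, `COc1cccc(NC(=O)C2Cc3cc(OC)c(OC)cc3C2=O)c1`: 38.9 ug/mL

All three values above come from a physicochemical assay, with a stated time of 30 min; on this read-out higher numbers stand for weaker inhibition and lower numbers for stronger inhibition. Compound 1 and compound 2 differ by methyl in place of hydrogen on a saturated chain carbon bound to an oxygen on an aromatic ring; the step of a 1.0-fold lower number from compound 1 to compound 2 (0.01 log units; within the scatter), so the two values are not distinguishable here. Compound 3 shares the same change of core with compound 1 as described by 3-methoxyphenyl in place of 4-methoxyphenyl on an amide-type nitrogen, and the step of a 1.3-fold lower number from compound 1 to compound 3 (0.10 log units; within the scatter). The values of compound 2 and compound 3 likewise lie within the scatter of each other, so no order among the three is claimed.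

Compound 4, `CCOc1cccc(NC(=O)C2Cc3cc(OC)c(OC)cc3C2=O)c1`, is not yet measured in this assay. It differs from compound 3 by methyl in place of hydrogen on a saturated chain carbon bound to an oxygen on an aromatic ring; this is the same change already seen from compound 1 to compound 2, made on the core of compound 3 rather than that of compound 1, and the place is described in identical words for both pairs. For the measured compounds named here, the one measured instance of the change gave a step within the scatter.

Compound 4 is therefore expected to sit close to compound 3, with an expected step of a 1.0-fold lower number from compound 3 to compound 4 (0.01 log units; within the scatter), because a 1.0-fold lower number from compound 1 to compound 2 (0.01 log units; within the scatter) was flat. The estimate rests on a single precedent and on a different core, so the range is kept wide. For compound 4 the expected value in this assay is 38 ug/mL, with an expected range from 22 ug/mL to 65 ug/mL.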

Compound 4, half-maximal inhibitory concentration: 44.9 ug/mL
Compound 4: the middle estimate sits 1.2-fold (0.07 log units) below what was measured, within the range that was stated.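

In this assay, for the compounds shown here, ethoxy in place of methoxy on the core of compound 3 gives a 1.2-fold higher number from compound 3 to compound 4 (0.06 log units; within the scatter) and leaves no step that can be told from repeat-measurement noise, and the same change on the core of compound 1 gives a 1.0-fold lower number from compound 1 to compound 2 (0.01 log units; within the scatter) with the same outcome, so in the two pairs available the flat result carries from one core to the other. This does not show that the change is without any effect on either core, since a real difference smaller than the scatter would go unseen here, and two pairs say nothing about other cores or about other changes at this place. No measurement on hand bears on why the change is flat in these two pairs.

Open, on these data alone, is whether a longer chain such as propoxy or butoxy, or a different group such as an amine or a carboxylic acid in place of the alkoxy group, would give a step beyond the scatter in this assay on either core. The four compounds shown all lie close together on this read-out, so they do not yet indicate which part of the structure, if any, can move the number.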